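Methyl for thiophen-3-yl: what to expect of compound 3

This account rests on a few compounds, and the source may have more. Where it says the series, first, only, none or still open, it means among the compounds named here.

Compound 1 `O=C(O)CCCC/C=C(\c1cccnc1)c1ccsc1` gives 31 nM in an assay (Equus caballus) for inhibition of Thromboxane-A synthase (Homo sapiens), using microsomes (a lower number here means a stronger inhibitor, a higher number a weaker inhibitor), the lowest of the two numbers recorded so far. Compound 2 `O=C(O)CCCC/C=C(/c1cccnc1)c1ccsc1` gives 62 nM in this assay; the step of a 2.0-fold higher number from compound 1 to compound 2 (0.30 log units; within the scatter) rests on the fact that compounds 1 and 2 differ only in the configuration as drawn and stays within the scatter, so the two compounds cannot be ordered against each other. Compound 3 `C/C(=C/CCCCC(=O)O)c1cccnc1` is not yet measured. It differs from compound 1 by methyl in place of thiophen-3-yl on a double-bonded chain carbon bound to an aromatic carbon and a double-bonded chain carbon. Going by the values given here, no measured step bears on this change: the single step recorded concerns configuration alone and leaves the group on the double-bonded chain carbon untouched. The expectation therefore rests only on the size of what leaves and what enters, and it is correspondingly wide. Relative to compound 1, compound 3 is expected to show the step of a 4.8-fold higher number from compound 1 to compound 3 (0.68 log units; beyond the scatter), towards a weaker inhibitor, with an estimated 150 nM in this assay and a range from 40 nM to 600 nM.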

Compound 3, half-maximal inhibitory concentration: 71 nM
For compound 3 the middle estimate is 2.1-fold (0.32 log units) above the measured one, within the range that was stated.
By their numbers in this assay, from the lowest: compounds 1, 2 and 3 (each within the scatter of the next, the first and the last beyond it).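

The change of thiophen-3-yl to methyl on this double-bonded chain carbon gives, in this assay, a 2.3-fold higher number from compound 1 to compound 3 (0.36 log units; beyond the scatter), so this position does respond to the group it carries, though only modestly. Removing the five-membered aromatic ring leaves much of the inhibition in place, with methyl alone on this carbon: compound 3 still gives 71 nM. Nothing available on the series explains this step, since the only supporting fact concerns configuration and not the exchange of groups.

Open, as far as these compounds go, is where ethyl or phenyl on this carbon would fall relative to compound 1 and compound 3, and whether any such group could go beyond thiophen-3-yl. Also open, from the compounds shown here alone, is how the double-bond configuration reads once methyl occupies this carbon.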